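This account rests on a few compounds, and the source may have more. Where it says the series, first, only, none or still open, it means among the compounds named here.

Compound 1 `CN(Cc1ccc2c(c1)OCCO2)c1nc(=O)c2cc(C(F)(F)F)cc([N+](=O)[O-])c2o1` is the methylated member of one core, and in an ADME assay on Vero cells (Chlorocebus sabaeus) for cytotoxicity, read by MTT assay, with a stated time of 48 h (on this read-out higher numbers stand for weaker inhibition and lower numbers for stronger inhibition), compound 1 gives 9.27 ug/mL. Its demethylated counterpart, compound 3 `O=c1nc(NCc2ccc3c(c2)OCCO3)oc2c([N+](=O)[O-])cc(C(F)(F)F)cc12`, gives 25.3 ug/mL in this assay, so that the step of a 2.7-fold higher number from compound 1 to compound 3 (0.44 log units; beyond the scatter) follows the change (hydrogen in place of methyl on a nitrogen on an aromatic ring). Compound 2 `COc1ccc(CN(C)c2cc(=O)c3cc(C(F)(F)F)cc([N+](=O)[O-])c3s2)cc1OC` carries a different core, and how the two cores differ is not broken down here. In this assay compound 2 reaches only a limit, > 64 ug/mL, which is the limit of > 64 ug/mL in this assay, at which 1 of the 3 values shown sits. Compound 4 `COc1ccc(CNc2cc(=O)c3cc(C(F)(F)F)cc([N+](=O)[O-])c3s2)cc1OC` differs from compound 2 by the same change, (hydrogen in place of methyl on a nitrogen on an aromatic ring). Since the earlier step raised the number, the step that the limit leaves unreadable from compound 2 to compound 4 is expected to lie in the same direction, and the starting point of compound 2 makes another limit likely. For compound 4 the value in this assay is therefore estimated at 110 ug/mL, between 45 ug/mL and 300 ug/mL.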

Compound 4, half-maximal inhibitory concentration: > 64 ug/mL
Compound 4 ended at the assay's limit; the forecaster's own chance of this, stated with the estimate: 75%; the middle value is on the limit's open side.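

Compound 2 and compound 4 both end at a limit rather than a number, so no step between them can be read: the limit of > 64 ug/mL in this assay, at which 2 of the 4 values shown sit.

The compounds shown leave open whether hydrogen in place of methyl changes the number at all on the core of compound 2.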